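Adding One Methyl to a Compound Known Only by a Limit

This account rests on a few compounds, and the source may have more. Where it says the series, first, only, none or still open, it means among the compounds named here.

Compound 1 `CCCSc1nc(C(C)c2c(F)cccc2Cl)cc(=O)[nH]1`: > 75000 nM (a limit)
Compound 2 `CCCSc1nc(C(C)c2c(F)cccc2Cl)c(C)c(=O)[nH]1`: > 1500 nM (a limit)
Compound 3 `CCCCSc1nc(C(C)c2c(F)cccc2Cl)c(C)c(=O)[nH]1`: > 1500 nM (a limit)

These results come from an ADME assay on MT4 cells (Homo sapiens) for activation, read by MTT assay (a lower number here means that less compound is tolerated, a higher number that more compound is tolerated), and all three are limits, not numbers. Compound 2 is therefore known only by a limit (> 1500 nM). Compound 4 `CCCSc1nc(C(CC)c2c(F)cccc2Cl)c(C)c(=O)[nH]1` differs from compound 2 by a single change (methyl in place of hydrogen on a saturated chain carbon, two bonds along the chain from two aromatic carbons) that turns methyl to ethyl. The closest measured change is a methyl on a saturated chain carbon (a step that the two limits leave unreadable from compound 2 to compound 3). The other is a methyl on an aromatic carbon (a step that the two limits leave unreadable from compound 1 to compound 2). Neither has a readable size, so no clear direction is expected in this assay and the expected step (a step that the limit leaves unreadable from compound 2 to compound 4) is only a rough estimate. Compound 4 is estimated at 5000 nM with an expected range from 1500 nM to 40000 nM and may again give only a limit.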

Compound 4, half-maximal cytotoxic concentration: > 3000 nM
Compound 4: a limit, no number; the forecaster's own chance of this, stated with the estimate: 75%; the middle value lies beyond the limit too.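

Compound 2 gives > 1500 nM as a limit. Compound 4 gives > 3000 nM as a limit too, so the step between these two compounds cannot be read. The compounds shown leave open how much of each compound the cells tolerate, and whether methyl to ethyl changes that at all.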